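Shortening the ester chain from benzyl to butyl

A few compounds are considered here, and "the series" means these few. Any claim that something is new, unique, unknown or untested is made for them only; others in the source may bear on it.

Compound 3 `C/C=C1/[C@H](O[C@@H]2O[C@H](CO)[C@@H](O)[C@H](O)[C@H]2O)OC=C(C(=O)OC)[C@H]1CC(=O)OCc1ccccc1` carries a benzyl ester on the shared core. In a functional assay on SK-BR-3 cells (Homo sapiens) for antiproliferative activity, read by MTT assay, with a stated time of 72 h (a lower number here means a stronger inhibitor, a higher number a weaker inhibitor), compound 3 reaches only a limit, > 15000 nM. Compound 1 `C/C=C1/[C@H](O[C@@H]2O[C@H](CO)[C@@H](O)[C@H](O)[C@H]2O)OC=C(C(=O)OC)[C@H]1CC(=O)OCCc1ccc2c(c1)OCCO2` likewise reaches only a limit in this assay, > 20000 nM. The step that the two limits leave unreadable from compound 1 to compound 3 therefore cannot be read, because both ends sit at limits (the limit of > 20000 nM in this assay, at which 1 of the 3 values shown sits, (the limit of > 15000 nM in this assay, at which 1 of the 3 values shown sits)). Going by the values given here, compound 2 `C/C=C1/[C@H](O[C@@H]2O[C@H](CO)[C@@H](O)[C@H](O)[C@H]2O)OC=C(C(=O)OC)[C@H]1CC(=O)OCCCCCCCCCCCCCCC` supplies the one numerical value of the set: in this assay compound 2 gives 1600 nM. Among the compounds with values here, no step to compound 2 is counted here, so its value stands on its own.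

Compound 4 `C/C=C1/[C@H](O[C@@H]2O[C@H](CO)[C@@H](O)[C@H](O)[C@H]2O)OC=C(C(=O)OC)[C@H]1CC(=O)OCCCC` differs from compound 3 by propyl in place of phenyl on a saturated chain carbon bound to an oxygen next to a carbonyl group. Within the data shown here, no measured step bears directly on this change; the only step available, from compound 1 to compound 3, is unreadable. Compound 2, with its pentadecyl ester, shows that an alkyl ester can give a measurable number, but the butyl chain of compound 4 is much shorter. The step of an at least 1.2-fold lower number from compound 3 to compound 4 (0.09 log units; that floor lies within the scatter) is expected to stay small, with compound 4 probably again close to a limit. Compound 4 is estimated at 12000 nM, within a range from 3000 nM to 50000 nM.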

Compound 4, half-maximal inhibitory concentration: > 15000 nM
Compound 4 gave a limit, no number (the forecaster's own chance of this, stated with the estimate: 55%); middle value at least 1.2-fold (0.09 log units) away from the limit.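

In this assay compound 4 also gives only a limit, > 15000 nM, so a short alkyl ester gives no measurable number here. Alkyl chain length at this position now has a readable effect: the pentadecyl and butyl esters are separated by an at least 9.3-fold higher number from compound 2 to compound 4 (0.97 log units; beyond the scatter). The steps linking compound 4 to compound 3 and compound 1 cannot be read, so the butyl ester cannot be ranked against either ester that carries a ring, since all three results are limits: the limit of > 15000 nM in this assay, at which 2 of the 4 values shown sit.

From the compounds shown here alone, the chain length at which a number first appears between butyl and pentadecyl remains open, and an octyl or a decyl ester would bear on this. It is also open how a chain carrying an amine or a carboxylic acid would behave, as nothing shown here has either group.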